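A few compounds are considered here, and "the series" means these few. Any claim that something is new, unique, unknown or untested is made for them only; others in the source may bear on it.

Values measured in a physicochemical assay for solubility, in phosphate buffer, at pH 7.4; on this read-out higher numbers stand for higher solubility and lower numbers for lower solubility:

- compound 1 `CC(C)Cn1cc(-c2ccnc3[nH]c(C4CCN(CC(=O)N(C)C)CC4)cc23)ccc1=O`: 390000 nM
- compound 2 `CC(C)n1cc(-c2ccnc3[nH]c(C4CCN(CC(=O)N(C)C)CC4)cc23)ccc1=O`: 110000 nM

Of these two compounds, compound 2 stands lower at 110000 nM, while compound 1 reads 390000 nM. Compound 3 `CN(C)C(=O)CN1CCC(c2cc3c(-c4ccc(=O)n(CCC5CCOCC5)c4)ccnc3[nH]2)CC1` has not yet been measured. It keeps the rest of compound 2 and differs as follows: 2-(oxan-4-yl)ethyl in place of isopropyl on an aromatic nitrogen. In short, 2-(oxan-4-yl)ethyl takes the place of isopropyl on an aromatic nitrogen.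

Among the compounds with values here, only one measured step bears on this change. It is a 3.5-fold lower number from compound 1 to compound 2 (0.55 log units; beyond the scatter), a modest step beyond the scatter, with isopropyl in place of isobutyl on that same nitrogen. Within the data shown here, one step sets no trend and the entering group has no measured precedent, so only a small upward move in this assay is expected. The expected step is a 1.6-fold higher number from compound 2 to compound 3 (0.21 log units; within the scatter), which would not clearly exceed the scatter. For compound 3 the estimate is 180000 nM, with an expected range of 60000 nM to 450000 nM.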

Compound 3, solubility: 370000 nM
Beside the measured number, compound 3's estimate is 2.1-fold (0.31 log units) below it; low and high end bracket the measured number.
By their numbers in this assay, from the lowest: compound 2; then compounds 3 and 1 (each within the scatter of the next).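

In this assay, the aromatic nitrogen carries the far larger 2-(oxan-4-yl)ethyl group with no loss against isopropyl, the change giving a modest rise (a 3.4-fold higher number from compound 2 to compound 3 (0.53 log units; beyond the scatter)). Set against the isobutyl of compound 1, the same group gives no step beyond the scatter (a 1.1-fold lower number from compound 1 to compound 3 (0.02 log units; within the scatter)), so compound 2, with its isopropyl, stands apart from both at the low end of these three compounds. Nothing shown accounts for this pattern.

Still open, on these data alone, is whether the ring oxygen of 2-(oxan-4-yl)ethyl plays any part, which a 2-cyclohexylethyl group on the same nitrogen would test. Also open, as far as these compounds go, is how a plain longer chain, or an amine or a carboxylic acid on that chain, would read in this assay against these compounds.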